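A Methoxy Group Added to the Core of Compound 1

This account rests on a few compounds, and the source may have more. Where it says the series, first, only, none or still open, it means among the compounds named here.

Measured compounds:
compound 1, `COc1c(/C=C2/C(=O)Nc3ccccc32)c2ccccc2n1-c1ccccc1`, with 3980 nM in a functional assay on cells (Melanoma cell, Homo sapiens) for cytotoxicity, with a stated time of 48 h; on this read-out higher numbers stand for weaker inhibition of growth and lower numbers for stronger inhibition of growth
compound 2, `COc1cc2c(c(OC)c1OC)/C(=C\c1c(Cl)[nH]c3ccccc13)C(=O)N2`, with 6610 nM in this assay

Of the compounds shown here, two have been measured in this assay. Compound 1 gives 3980 nM, the lowest of the two numbers, and compound 2 gives 6610 nM; the two values lie within the usual scatter of each other, so nothing separates them. Among the compounds with values here, the two structures differ in many places at once, so no single step between them can be read.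

Compound 3, `COc1ccc2c(c1)/C(=C\c1c(OC)n(-c3ccccc3)c3ccccc13)C(=O)N2`, has not yet been measured. It differs from compound 1 in one place: methoxy in place of hydrogen on an aromatic carbon. Within the data shown here, no step between measured compounds bears on a change of this kind, so there is no precedent in these data for its size or direction. On that basis the expected step is a 1.0-fold higher number from compound 1 to compound 3 (0.00 log units; within the scatter), no larger than the usual scatter. Compound 3 is therefore estimated at 4000 nM, within a range from 1500 nM to 11000 nM.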

Compound 3, concentration for total growth inhibition: 17000 nM
Estimate against measurement, compound 3: 4.3-fold (0.63 log units) below; measured number above the stated range.
By their numbers in this assay, from the lowest: compounds 1 and 2 (each within the scatter of the next); then compound 3.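

This position on the core of compound 1 is not indifferent to substitution. In this assay, within the data shown here, methoxy in place of hydrogen on an aromatic carbon of a six-membered aromatic ring of carbon only, part of a fused or bridged system of two rings, gives a 4.3-fold higher number from compound 1 to compound 3 (0.63 log units; beyond the scatter) as the first single-place change that can be read in these data, a modest step but one beyond the scatter, and it runs toward weaker inhibition of growth. Nothing measured here accounts for this rise, so the step stands as an observation only.

The compounds shown leave open whether the step belongs to methoxy itself or would also appear with another group on this carbon, such as a hydroxyl, a fluorine atom or an amine, any of which could move the number in either direction. They also leave open whether methoxy on another carbon of that ring would give a step of the same direction and size, and whether the same change would read alike on the core of compound 2, which carries methoxy groups of its own.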